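Swapping Bromo for Hexyl on the Sulfonamide Aryl Ring

The compounds below may be only part of what the source reports. "The series", "measured", "known", "first", "only" and "open" are said of these compounds alone.

For the measured compounds named here, compound 1 `CC(=O)Nc1nc(-c2cccc(NS(=O)(=O)c3ccc(Br)cc3)c2)cs1` gives 19.7% in a functional assay on A-375 cells (Homo sapiens) for antiproliferative activity, read by trypan blue exclusion, with a stated time of 48 h, tested at 5 uM (on this read-out lower numbers stand for a stronger effect and higher numbers for a weaker effect at the one concentration tested), the lowest of the two numbers measured so far. Compound 2 `C#Cc1ccc(S(=O)(=O)Nc2cccc(-c3csc(NC(C)=O)n3)c2)cc1` gives 38.3% in this assay. Going by the values given here, the one step that bears on the present change, a number 18.6 percentage points higher from compound 1 to compound 2 (beyond the scatter), shows that replacing the bromo at this spot can move the read-out upward beyond the scatter. Compound 3 `CCCCCCc1ccc(S(=O)(=O)Nc2cccc(-c3csc(NC(C)=O)n3)c2)cc1` differs from compound 1 in this way: hexyl in place of bromo on an aromatic carbon. Among the compounds with values here, no measured step covers hexyl, so the step in this assay is expected to point upward, roughly as a number 22.3 percentage points higher from compound 1 to compound 3 (beyond the scatter). Compound 3 is therefore estimated at 42%, ranging from 22% to 65%.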

Compound 3, a percentage reported as activity, at one concentration (the size of the read-out at that concentration, not a potency): < 1%
Compound 3: no number, only a limit; the forecaster's own chance of this, stated with the estimate: 0%; middle value at least 41 percentage points from the limit.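

Replacing bromo at this position does not always raise the read-out: hexyl in place of bromo gives a number at least 18.7 percentage points lower from compound 1 to compound 3 (beyond the scatter), the opposite direction to ethynyl. Hexyl in place of ethynyl gives a number at least 37.3 percentage points lower from compound 2 to compound 3 (beyond the scatter), so the group entering at this carbon can move the read-out a long way. The result for compound 3 in this assay is a limit of the assay and not a number: the limit of < 1% in this assay, at which 1 of the 3 values shown sits.

Going by these compounds, how far compound 3 lies past that limit stays open. So does whether a butyl group, a longer chain such as octyl, or a terminal amine on the hexyl chain would give a read-out as low.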